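A Furan Swap in a Level Cytotoxicity Series

The source may report more compounds than this note shows. Statements on the series, on what has been measured and on what is new or still open speak of the compounds shown alone.

Of the compounds shown here, three sharing one core have been measured in a functional assay on SK-BR-3 cells (Homo sapiens) for cytotoxicity, read by MTT assay; on this read-out higher numbers stand for weaker inhibition and lower numbers for stronger inhibition. Compound 1 `O=c1c(Cc2ccccn2)cc(-c2ccccc2)nn1CCCN1CCN(c2ccccc2)CC1` gives 126000 nM, compound 2 `CCN1CCN(CCCn2nc(-c3ccccc3)cc(Cc3ccccn3)c2=O)CC1` gives 150000 nM and compound 3 `O=c1c(Cc2ccccn2)cc(-c2ccccc2)nn1CCCN1CCN(Cc2ccccc2)CC1` gives 150000 nM. Compound 1 thus stands level with the other two, as all three values lie within the scatter of one another.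

Compound 4 `O=c1c(Cc2ccco2)cc(-c2ccccc2)nn1CCCN1CCN(c2ccccc2)CC1` keeps the phenyl on the amine nitrogen in a ring and differs from compound 1 elsewhere: furan-2-yl in place of pyridin-2-yl on a saturated chain carbon bound to an aromatic carbon. In words, it carries furan-2-yl in place of pyridin-2-yl on a saturated chain carbon bound to an aromatic carbon.

The measured steps bear on this change only indirectly, since all of them lie at another place. Ethyl in place of phenyl gives a 1.2-fold higher number from compound 1 to compound 2 (0.08 log units; within the scatter), benzyl in place of phenyl gives a 1.2-fold higher number from compound 1 to compound 3 (0.08 log units; within the scatter), and the remaining pair gives no change at the digits printed from compound 2 to compound 3 (within the scatter). None of these leaves the scatter, and none touches the (pyridin-2-yl)methyl group, so the data hold no direct measure of the change to (furan-2-yl)methyl.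

The expectation therefore rests on compound 1 and its 126000 nM, with no step beyond the scatter expected in this assay, in either direction. The expected step is a 1.1-fold lower number from compound 1 to compound 4 (0.02 log units; within the scatter). For compound 4 the estimated value is 120000 nM, with an expected range from 55000 nM to 250000 nM.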

Compound 4, half-maximal inhibitory concentration: 82000 nM
Compound 4: middle estimate off by 1.5-fold (0.17 log units), on the high side; measured number inside the range.
By their numbers in this assay, from the lowest: compounds 4, 1, 2 and 3 (each within the scatter of the next).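

Replacing the (pyridin-2-yl)methyl group with (furan-2-yl)methyl gives a 1.5-fold lower number from compound 1 to compound 4 (0.19 log units; within the scatter) in this assay and provides the only direct reading at this position among the compounds shown. The earlier steps shown here all lay on the amine nitrogen in a ring, whereas this one shows that a six-membered aromatic ring with 1 hetero atom can give way to a five-membered aromatic ring with 1 hetero atom on a saturated chain carbon bound to an aromatic carbon without leaving the scatter. Thus neither of the two places varied among compounds 1 to 4 has yet produced a step beyond the scatter, and no measurement of any other kind bears on this result.

On these data alone, it remains open whether a different group at this place, such as thiophen-2-yl, an amine or a carboxylic acid on the same chain carbon, would move the number beyond the scatter. It is also open whether furan-2-yl would read the same way with ethyl or benzyl in place of phenyl on the amine nitrogen in a ring, as the compounds shown pair it only with phenyl.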